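Trimming the Side Chain of Compound 3

The source may report more compounds than this note shows. Statements on the series, on what has been measured and on what is new or still open speak of the compounds shown alone.

Three compounds share the same core, a benzene carrying a carbon that bears two thiopropanoic acid arms, and differ in the side chain attached to the ring. In an assay on membranes from lung (Cavia porcellus) for binding affinity to cysteinyl leukotriene receptor (Homo sapiens) (on this read-out higher numbers stand for weaker inhibition and lower numbers for stronger inhibition), compound 3 `CCCCCCCCCCCCCOc1cccc(C(SCCC(=O)O)SCCC(=O)O)c1` gives 530 nM. Compound 2 `CCCCCCCCCCC#Cc1ccccc1C(SCCC(=O)O)SCCC(=O)O` gives 2520 nM in this assay. Compound 1 `CCCCc1ccccc1C(SCCC(=O)O)SCCC(=O)O` gives > 20000 nM in this assay, which is a limit of the assay and not a number. Within the data shown here, of the two numbers known, compound 3 stands at the lower end, and its gap to compound 2 lies beyond the usual scatter of repeated measurements.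

Compound 4 `CCCCCCCCCCCOc1cccc(C(SCCC(=O)O)SCCC(=O)O)c1` has not yet been measured in this assay. It differs from compound 3 in one place: hydrogen in place of ethyl on a saturated chain carbon, ten or more bonds along the chain from an oxygen on an aromatic ring, in words, hydrogen in place of ethyl on a saturated chain carbon, ten or more bonds along the chain from an oxygen on an aromatic ring. Among the measured compounds shown here, no step between two measured compounds matches this change, so the expectation rests only on the three values shown. The shorter chain of compound 4 is expected to give a modest rise in the number, of a size close to the edge of the scatter, as the step of a 1.7-fold higher number from compound 3 to compound 4 (0.23 log units; within the scatter) describes. Compound 4 is therefore estimated at 900 nM in this assay, with a plausible range from 300 nM to 3000 nM.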

Compound 4, inhibition constant: 78 nM
Estimate against measurement, compound 4: 12-fold (1.06 log units) above; measured number below the stated range.
By their numbers in this assay, from the lowest: compound 4; then compound 3; then compound 2. At a limit, above all of these: compound 1.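

In this assay, replacing ethyl with hydrogen on a saturated chain carbon gives a 6.8-fold lower number from compound 3 to compound 4 (0.83 log units; beyond the scatter). The far end of this chain therefore matters: a change this distant from the shared core moves the read-out beyond the usual scatter, and here the shorter chain gives the stronger inhibition, so a longer chain is not automatically better in this pair. The data show only the size and direction of this step, and no measurement shown explains why removing these two carbons strengthens inhibition.

Among these compounds, with only two chain lengths compared directly, this single step cannot establish a trend, and it remains open whether a still shorter chain would strengthen inhibition further or weaken it again. On these data alone, it is also open whether the chain end tolerates anything other than plain carbon and hydrogen, such as a hydroxyl group, an amine or a carboxylic acid placed at the tip of the chain.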